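The compounds below may be only part of what the source reports. "The series", "measured", "known", "first", "only" and "open" are said of these compounds alone.

In a functional assay on U-373MG ATCC cells (Homo sapiens) for inhibition, read by MTT assay, with a stated time of 72 h (on this read-out lower numbers stand for stronger inhibition and higher numbers for weaker inhibition), compound 1 (`CC1(C)CC(NC(=O)Nc2ccccc2)c2cc(Cl)ccc2O1`) gives 68000 nM and compound 2 (`CC(C)NC(=S)NC1CC(C)(C)Oc2ccc(Cl)cc21`) gives 57000 nM. These two values lie within the scatter of each other, so compound 2 cannot be separated from compound 1. Compound 3 (`CC(=O)NC1CC(C)(C)Oc2ccc(Cl)cc21`) keeps the core of compound 2 and carries an acetyl on the amine nitrogen: a group of 3 heavy atoms (2 carbon, 1 oxygen; no ring) in place of a group of 6 heavy atoms (4 carbon, 1 nitrogen, 1 sulfur; no ring), on an amine nitrogen. Within the data shown here, no step between measured compounds is available, so the expectation rests on this structural change alone. A small shift toward weaker inhibition is expected, a 1.6-fold higher number from compound 2 to compound 3 (0.20 log units; within the scatter), in this assay. Compound 3 is estimated at 90000 nM, with an expected range of 35000 nM to 220000 nM.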

Compound 3, half-maximal inhibitory concentration: > 100000 nM
Compound 3 ended at the assay's limit; the forecaster's own chance of this, stated with the estimate: 25%; middle value at least 1.1-fold (0.04 log units) away from the limit.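

In this assay compound 3 gives > 100000 nM, a limit and not a number. On the amine nitrogen, acetyl in place of the larger group gives an at least 1.7-fold higher number from compound 2 to compound 3 (0.24 log units; that floor lies within the scatter), and methyl in place of anilino on the carbonyl carbon gives an at least 1.4-fold higher number from compound 1 to compound 3 (0.16 log units; that floor lies within the scatter). Acetyl thus leaves no readable value, whereas the two larger groups do, but the true size of both steps stays unknown: the limit of > 100000 nM in this assay, at which 1 of the 3 values shown sits.

Open, on these data alone, is whether a longer acyl chain on this nitrogen would return a readable value. As far as these compounds go, the free amine at this place also remains open.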